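From an Aryl Ether Back to a Direct Biaryl Link

The source may report more compounds than this note shows. Statements on the series, on what has been measured and on what is new or still open speak of the compounds shown alone.

Of the compounds shown here, three built on one shared core have been measured in a physicochemical assay for solubility, with a stated time of 18 h, at pH 7.4; a lower number here means a less soluble compound, a higher number a more soluble compound. Compound 1 `COc1cccc(CNCCCNc2ccnc3cc(-c4ccc(F)cc4)ccc23)c1O` carries a 4-fluorophenyl group directly on the core and gives 32000 nM. Compound 2 `COc1cccc(CNCCCNc2ccnc3cc(Oc4ccc(F)cc4)ccc23)c1O` carries 4-fluorophenoxy instead and gives 14500 nM. Compound 3 `COc1ccccc1Oc1ccc2c(NCCCNCc3cccc(OC)c3O)ccnc2c1` carries 2-methoxyphenoxy and gives 14500 nM. Compound 3 thus stands level with compound 2, the two together at the lowest of the three numbers: the step of no change at the digits printed from compound 2 to compound 3 (within the scatter) and the step of a 2.2-fold lower number from compound 1 to compound 3 (0.34 log units; beyond the scatter) show the whole spread.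

Compound 4 `COc1cccc(CNCCCNc2ccnc3cc(-c4ccc(C(F)(F)F)cc4)ccc23)c1O` differs from compound 3 in one place: 4-(trifluoromethyl)phenyl in place of 2-methoxyphenoxy on an aromatic carbon. This change has two parts. Replacing a phenoxy link by a direct aryl link is mirrored by the step of a 2.2-fold lower number from compound 1 to compound 3 (0.34 log units; beyond the scatter) run backwards, a modest gain. Swapping fluorine for trifluoromethyl on that ring is covered by no measured step. A modest rise is therefore expected, a 1.5-fold higher number from compound 3 to compound 4 (0.18 log units; within the scatter), with wide uncertainty. Compound 4 is estimated at 22000 nM in this assay, within a range from 7000 nM to 60000 nM.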

Compound 4, solubility: 32000 nM
For compound 4 the middle estimate is 1.5-fold (0.16 log units) below the measured one; the measured number falls inside the stated range.
By their numbers in this assay, from the lowest: compounds 2 and 3 (each within the scatter of the next); then compounds 1 and 4 (each within the scatter of the next).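

In this assay, trifluoromethyl in place of fluoro on the directly attached phenyl ring gives no change at the digits printed from compound 1 to compound 4 (within the scatter), so this swap does not separate the two direct aryl compounds. The other two steps, a 2.2-fold higher number from compound 3 to compound 4 (0.34 log units; beyond the scatter) and a 2.2-fold higher number from compound 2 to compound 4 (0.34 log units; beyond the scatter), extend a split first seen with compound 1: among these four, compound 1 and compound 4, with a direct aryl link, both stand above compound 2 and compound 3, with a phenoxy link, and no compound goes against this. Nothing available explains this split.

Going by these compounds, how a direct 2-methoxyphenyl group would compare with the 2-methoxyphenoxy group of compound 3 stays open. Also open, on these data alone, is whether a carboxylic acid or an amine on that directly attached ring would keep the number at this level.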